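A Methyl Added to the Isopropyl Group of Compound 3

This account rests on a few compounds, and the source may have more. Where it says the series, first, only, none or still open, it means among the compounds named here.

In an ADME assay on C8166 cells (Homo sapiens) for cytotoxicity, read by MTT assay (a higher number here means that more compound is tolerated, a lower number that less compound is tolerated), compound 3 `CC(C)n1cc(C(=O)O)c(=O)c2c(O)c(Cc3cccc(Cl)c3F)ccc21` gives 26500 nM. Its nearest neighbour, compound 1 `CCCn1cc(C(=O)O)c(=O)c2c(O)c(Cc3cccc(Cl)c3F)ccc21`, gives 24200 nM, and compound 2 `CCCCCn1cc(C(=O)O)c(=O)c2c(O)c(Cc3cccc(Cl)c3F)ccc21` gives 39900 nM, so all three lie within the scatter of one another. Compound 4 `CCC(C)n1cc(C(=O)O)c(=O)c2c(O)c(Cc3cccc(Cl)c3F)ccc21` differs from compound 3 by methyl in place of hydrogen on a saturated chain carbon, two bonds along the chain from an aromatic nitrogen. The bearing steps are those among the chains on the aromatic nitrogen: a 1.1-fold higher number from compound 1 to compound 3 (0.04 log units; within the scatter), a 1.6-fold higher number from compound 1 to compound 2 (0.22 log units; within the scatter) and a 1.5-fold lower number from compound 2 to compound 3 (0.18 log units; within the scatter). Each stays within the scatter, so no step beyond it is expected in this assay, and the estimated step is a 1.1-fold higher number from compound 3 to compound 4 (0.05 log units; within the scatter). Compound 4 is estimated at 30000 nM, with an expected range from 17000 nM to 50000 nM.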

Compound 4, half-maximal cytotoxic concentration: 30700 nM
Beside the measured number, compound 4's estimate is 1.0-fold (0.01 log units) below it; the measured number falls inside the stated range.
By their numbers in this assay, from the lowest: compounds 1, 3, 4 and 2 (each within the scatter of the next).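

In this assay, methyl in place of hydrogen on a saturated chain carbon, two bonds along the chain from an aromatic nitrogen, gives a small step (a 1.2-fold higher number from compound 3 to compound 4 (0.06 log units; within the scatter)). The sec-butyl chain also stays close to the straight chains, pentyl (a 1.3-fold lower number from compound 2 to compound 4 (0.11 log units; within the scatter)) and propyl (a 1.3-fold higher number from compound 1 to compound 4 (0.10 log units; within the scatter)). Across compounds 1, 2, 3 and 4, then, neither branching nor chain length on the aromatic nitrogen moves any step beyond the scatter.

From the compounds shown here alone, whether a chain ending in an amine, or a cyclopropyl ring, on the aromatic nitrogen would stay within the scatter remains open. No evidence bears on the closeness of these numbers.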